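Moving the Ring Nitrogen in a Nitro-Bearing Oxindole Pair

The compounds below may be only part of what the source reports. "The series", "measured", "known", "first", "only" and "open" are said of these compounds alone.

Compound 1, `O=C1Nc2ccc([N+](=O)[O-])cc2C1=Cc1ccncc1`: "not toxic" (no number reported)
Compound 2, `COC(=O)Nc1ccc2c(c1)C(=Cc1ccc([N+](=O)[O-])cc1)C(=O)N2`: > 100000 nM

Of the compounds shown here, two have so far been tested in an ADME assay on A549 cells (Homo sapiens) for cytotoxicity, read by MTT assay, with a stated time of 72 h; a lower number here means a stronger inhibitor, a higher number a weaker inhibitor. Compound 1, `O=C1Nc2ccc([N+](=O)[O-])cc2C1=Cc1ccncc1`, gives "not toxic" (no number reported) in this assay, a qualitative outcome with no number attached. For compound 2, `COC(=O)Nc1ccc2c(c1)C(=Cc1ccc([N+](=O)[O-])cc1)C(=O)N2`, the outcome in this assay is > 100000 nM, which is a limit of the assay and not a number. For the measured compounds named here, compound 1 therefore stands without a number of its own, and the one further value shown is the limit of > 100000 nM in this assay, at which 1 of the 2 values shown sits.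

Compound 3, `O=C1Nc2ccc([N+](=O)[O-])cc2C1=Cc1cccnc1`, has the same atoms as compound 1 joined differently: pyridin-3-yl in place of pyridin-4-yl on a double-bonded chain carbon bound to a double-bonded ring carbon. No measured step of this kind exists among these compounds, so no change beyond the usual scatter in this assay is expected in either direction. Compound 3 is expected to give 100000 nM in this assay, within a likely range from 30000 nM to 300000 nM, and most probably only a limit will be reported.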

Compound 3, half-maximal inhibitory concentration: 429000 nM
Estimate against measurement, compound 3: 4.3-fold (0.63 log units) below; the whole stated range lies below it.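

In this assay, for the compounds shown here, compound 1 gives "not toxic" (no number reported) and compound 3 gives 429000 nM, so no step from compound 1 to compound 3 can be read. On these data alone, whether exchanging pyridin-4-yl for pyridin-3-yl changes the cytotoxicity value at all remains open.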